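Swapping one heteroaromatic ring for another at the chain end

The source may report more compounds than this note shows. Statements on the series, on what has been measured and on what is new or still open speak of the compounds shown alone.

The series shares a core carrying two benzyloxy groups, with a heteroaromatic ring attached through a short chain. In a functional assay on MCF7 cells (Homo sapiens) for inhibition, read by MTT assay, with a stated time of 72 h (a higher number here means a weaker inhibitor, a lower number a stronger inhibitor), compound 1 `O=C1O/C(=C\Cn2ncc(=O)[nH]c2=O)C(OCc2ccccc2)=C1OCc1ccccc1` gives 3770 nM. Compound 2 `Nc1ncn(C/C=C2\OC(=O)C(OCc3ccccc3)=C2OCc2ccccc2)c(=O)n1` gives 3490 nM in this assay, and the saturated analogue compound 3 `Nc1ccn(CCC2(N)OC(=O)C(OCc3ccccc3)=C2OCc2ccccc2)c(=O)n1` gives 32000 nM. Compound 2 and compound 1 lie within the scatter of each other, while compound 3 sits far apart from both; compound 2 therefore stands at the lower side of the three numbers without being separable from compound 1.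

The unmeasured compound 4 `O=C1O/C(=C\Cn2c(=O)[nH]c(=O)[nH]c2=O)C(OCc2ccccc2)=C1OCc1ccccc1` differs from compound 2 by a group of 9 heavy atoms (3 carbon, 3 nitrogen, 3 oxygen; one six-membered aromatic ring with 3 hetero atoms) in place of a group of 8 heavy atoms (3 carbon, 4 nitrogen, 1 oxygen; one six-membered aromatic ring with 3 hetero atoms), on a saturated chain carbon bound to a double-bonded chain carbon. Going by the values given here, the one measured step that bears on this change is the exchange of the ring at the same place from compound 1 to compound 2, which gave a 1.1-fold lower number from compound 1 to compound 2 (0.03 log units; within the scatter). That precedent suggests the core tolerates a change of the heteroaromatic ring at this position without a shift beyond the scatter, and nothing in the data points the other way. Compound 4 is accordingly expected to give about 3700 nM in this assay, with a range from 1500 nM to 9000 nM. This estimate means an expected 1.1-fold higher number from compound 2 to compound 4 (0.03 log units; within the scatter), a step not beyond the scatter.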

Compound 4, half-maximal inhibitory concentration: 17800 nM
For compound 4 the middle estimate is 4.8-fold (0.68 log units) below the measured one, outside the stated range (above it).
By their numbers in this assay, from the lowest: compounds 2 and 1 (each within the scatter of the next); then compounds 4 and 3 (each within the scatter of the next).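

The ring at the chain end proves not to be freely exchangeable: in this assay the change gives a 5.1-fold higher number from compound 2 to compound 4 (0.71 log units; beyond the scatter) and a 4.7-fold higher number from compound 1 to compound 4 (0.67 log units; beyond the scatter) as well, both modest but beyond the scatter, whereas the earlier exchange at this place gave a 1.1-fold lower number from compound 1 to compound 2 (0.03 log units; within the scatter) and stayed within it. The position on a saturated chain carbon bound to a double-bonded chain carbon therefore does respond to which ring it carries, and the ring of compound 4, with its 9 heavy atoms, 3 double bonds outside aromatic rings and 2 hydrogen-bond donors, is the one that separates from the two others. Nothing available accounts for why this ring stands apart while the other exchange left the number within the scatter.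

On these data alone, whether the same step would appear with a longer chain between the shared core and the ring, or with an amine or a carboxylic acid on the ring of compound 4, remains open. Also open, as far as these compounds go, is whether it would hold if hydroxyl groups took the place of the two benzyloxy groups on the shared core.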